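The source may report more compounds than this note shows. Statements on the series, on what has been measured and on what is new or still open speak of the compounds shown alone.

Measured compounds:
Compound 1, `O=C(OCCCc1cn(-c2ccnc3cc(Cl)ccc23)nn1)c1ccccc1`, gives 1200000 nM in an ADME assay on HepG2 cells (Homo sapiens) for cytotoxicity, read by MTT assay, with a stated time of 24 h; on this read-out lower numbers stand for higher toxicity in this test and higher numbers for lower toxicity in this test.
Compound 2, `CC(C)(C)c1ccc(C(=O)OCCCc2cn(-c3ccnc4cc(Cl)ccc34)nn2)cc1`, gives > 2230000 nM in this assay; this value is a limit of the assay and not a number.
Compound 3, `CC(C)(C)c1ccc(C(=O)OCc2cn(-c3ccnc4cc(Cl)ccc34)nn2)cc1`, gives > 2380000 nM in this assay; this value too is a limit of the assay and not a number.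

Compound 1 and compound 2 share one core and differ in one place: hydrogen in place of tert-butyl on an aromatic carbon. The step that this change made is an at least 1.8-fold lower number from compound 2 to compound 1 (0.26 log units; that floor lies within the scatter). Its size is given only as a floor because compound 2 sits at the limit of > 2230000 nM in this assay, at which 1 of the 3 values shown sits.

Compound 3 carries the same tert-butyl-bearing group as compound 2 on a different core; how the two cores differ is not broken down here. Compound 3 sits at the limit of > 2380000 nM in this assay, at which 1 of the 3 values shown sits.

Compound 4, `O=C(OCc1cn(-c2ccnc3cc(Cl)ccc23)nn1)c1ccccc1`, is not yet measured in this assay. It stands to compound 3 as compound 1 stands to compound 2: hydrogen in place of tert-butyl on an aromatic carbon. The place is the same in both pairs, so this is the same change. The step is expected to be of the same order as the earlier one, an at least 1.8-fold lower number from compound 3 to compound 4 (0.26 log units; that floor lies within the scatter), resting on the measured step from compound 2 to compound 1 and on the limit at which compound 3 sits.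

Compound 4 is therefore estimated at 1300000 nM in this assay, expected between 600000 nM and 2500000 nM.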

Compound 4, half-maximal cytotoxic concentration: > 2740000 nM
Compound 4 ended at the assay's limit; the forecaster's own chance of this, stated with the estimate: 30%; at least 2.1-fold (0.32 log units) between middle value and limit.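

Compound 3 and compound 4 both stand at limits of this assay, so no step can be read between them, and the change from 4-(tert-butyl)phenyl to phenyl has no readable size on this core. The compounds shown leave open what numbers lie behind the limits of compound 2, compound 3 and compound 4, and whether this change acts alike on both cores.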